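Notes on the methyl-to-hydrogen step and compound 4

The compounds below may be only part of what the source reports. "The series", "measured", "known", "first", "only" and "open" are said of these compounds alone.

Measured so far:
compound 1 `Cc1ccnc(/C(N)=N/NC(=S)N2CCN(c3ccccn3)CC2)c1` — 76%
compound 2 `N/C(=N\NC(=S)N1CCCCC1)c1ccccn1` — 85.8%
compound 3 `Cc1ccnc(/C(N)=N/NC(=S)N2CCCCC2)c1` — 81.2%

All three numbers come from a functional assay on A-375 cells (Homo sapiens) for cytotoxicity, read by MTT assay, with a stated time of 72 h, tested at 10 uM; a lower number here means less inhibition of growth, a higher number more inhibition of growth at the concentration tested. In this assay compound 1 gives 76%, compound 3 gives 81.2% and compound 2 gives 85.8%; the three values lie within the usual scatter of one another, so no ordering among them is claimed.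

One single-point change is measured. From compound 3 to compound 2 the change is hydrogen in place of methyl on an aromatic carbon, and it gives a number 4.6 percentage points higher from compound 3 to compound 2 (within the scatter). How the core of compound 1 differs from the core of compound 3 is not broken down here.

Compound 4 `N/C(=N\NC(=S)N1CCN(c2ccccn2)CC1)c1ccccn1` is not yet measured. From compound 1 to compound 4 the change is hydrogen in place of methyl on an aromatic carbon, the same change as from compound 3 to compound 2, at the same place in the same words. The step from compound 1 to compound 4 is expected to be a number 4 percentage points higher from compound 1 to compound 4 (within the scatter), which rests on the earlier step of a number 4.6 percentage points higher from compound 3 to compound 2 (within the scatter). Compound 4 is therefore estimated at 80% in this assay, expected within 70% to 90%.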

Compound 4, percent growth inhibition at one concentration: 74.4%
For compound 4 the middle estimate is 5.6 percentage points above the measured one; the measured number falls inside the stated range.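

The change from 4-methylpyridin-2-yl to pyridin-2-yl gives a number 1.6 percentage points lower from compound 1 to compound 4 (within the scatter) in this assay at the tested concentration. Carried from one core to the other, the change gives two steps that cannot be told apart: the same change on two cores in this assay, a number 4.6 percentage points higher (within the scatter) from compound 3 to compound 2 and a number 1.6 percentage points lower (within the scatter) from compound 1 to compound 4, 6.2 percentage points apart, within the scatter of two such steps. This shows that, on these two cores, the change leaves the number within the scatter both times, but it does not fix a direction for the step, as the two steps have opposite signs, and it does not show that the change would stay this small on any other core.

The compounds shown carry only methyl or hydrogen at this place, so how an ethyl group, a methoxy group, an amine or a carboxylic acid there would read in this assay remains open. Also open, going by these compounds, is whether the pairs would stay this close at concentrations lower than the single one tested, where a full concentration series could separate them.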